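The compounds below may be only part of what the source reports. "The series", "measured", "known", "first", "only" and "open" are said of these compounds alone.

Compound 1 `COC(=O)c1ccccc1-c1cnc(C(=O)CCCCCCc2ccccc2)o1` gives 60 nM in an assay (Rattus norvegicus) for inhibition of Fatty-acid amide hydrolase 1 (Homo sapiens); on this read-out lower numbers stand for stronger inhibition and higher numbers for weaker inhibition. Compound 2 `COC(=O)c1ccc(-c2cnc(C(=O)CCCCCCc3ccccc3)o2)cc1` gives 40 nM. Compound 3 `O=C(CCCCCCc1ccccc1)c1ncc(-c2ccc(O)cc2)o1` gives 140 nM.

Compound 3 stands highest of the three numbers in this assay, above compound 1 and further above compound 2, and both gaps lie beyond the scatter. Compound 4 `O=C(CCCCCCc1ccccc1)c1ncc(-c2cncnc2)o1` differs from compound 3 in one place: pyrimidin-5-yl in place of 4-hydroxyphenyl on an aromatic carbon. Within the data shown here, only one measured step touches this aromatic carbon: a 3.5-fold higher number from compound 2 to compound 3 (0.54 log units; beyond the scatter). Among the measured compounds shown here, it shows that the group on this carbon matters and that the 4-hydroxyphenyl was the weaker of the two groups tried; no measured step involves pyrimidin-5-yl itself, so the expectation rests on this single step alone. With the hydrogen-bond donor leaving and a six-membered aromatic ring with two nitrogen acceptors entering, a number somewhat lower than that of compound 3 is expected, roughly undoing the earlier rise: a 3.1-fold lower number from compound 3 to compound 4 (0.49 log units; beyond the scatter). Compound 4 is accordingly estimated at 45 nM, with a range from 12 nM to 170 nM.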

Compound 4, inhibition constant: 22 nM
Compound 4: middle estimate off by 2.0-fold (0.31 log units), on the high side, and the stated range covers the measured number.
By their numbers in this assay, from the lowest: compounds 4, 2 and 1 (each within the scatter of the next, the first and the last beyond it); then compound 3.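

The step at this position, a 6.4-fold lower number from compound 3 to compound 4 (0.80 log units; beyond the scatter), shows that a low number in this assay does not depend on a phenyl ring carrying methoxycarbonyl: a pyrimidin-5-yl ring with no such ester serves as well, since compound 4 at 22 nM and compound 2 at 40 nM lie within the usual scatter of each other. Among these three groups, the 4-hydroxyphenyl of compound 3 is the one that stands apart with the higher number. The change removes a hydroxy group and brings in ring nitrogens together, and nothing available here explains the gain.

The compounds shown cannot separate those two parts of the change. An unsubstituted phenyl or a pyridin-3-yl at this carbon would help to tell them apart.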